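This account rests on a few compounds, and the source may have more. Where it says the series, first, only, none or still open, it means among the compounds named here.

Compound 1, `CC(C)c1ccc(-c2nc(SCc3cn(CC(=O)NC(=O)Nc4ccccn4)nn3)nc(Nc3cccc([N+](=O)[O-])c3)c2C#N)cc1`, gives 31300 nM in a functional assay on ECa-109 cells (Homo sapiens) for inhibition, read by MTT assay, with a stated time of 72 h; a higher number here means a weaker inhibitor, a lower number a stronger inhibitor.
Compound 2, `CC(C)c1ccc(-c2nc(SCc3cn(CC(=O)NC(=O)Nc4ccccn4)nn3)nc(Nc3ccccc3F)c2C#N)cc1`, gives 15500 nM in this assay.
Compound 3, `COc1ccc(Nc2nc(SCc3cn(CC(=O)NC(=O)Nc4ccccn4)nn3)nc(-c3ccc(C(C)C)cc3)c2C#N)cc1`, gives 5420 nM in this assay.

Of the three measured compounds, compound 3 stands at the lowest number, with compound 2 nearest and compound 1 furthest. The three steps all alter the aryl group on the nitrogen of the shared core: a 2.0-fold lower number from compound 1 to compound 2 (0.31 log units; beyond the scatter), a 5.8-fold lower number from compound 1 to compound 3 (0.76 log units; beyond the scatter) and a 2.9-fold lower number from compound 2 to compound 3 (0.46 log units; beyond the scatter). Each is modest yet beyond the scatter, so this part of the molecule clearly moves the read-out.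

Compound 4, `CC(C)c1ccc(Nc2nc(SCc3cn(CC(=O)NC(=O)Nc4ccccn4)nn3)nc(-c3ccc(C(C)C)cc3)c2C#N)cc1`, keeps the 4-substituted anilino pattern of compound 3 but carries a different group there: isopropyl in place of methoxy on an aromatic carbon. Going by the values given here, no measured step exchanges methoxy for isopropyl, so the direction cannot be read from the data; the earlier steps show only that changes on this ring shift the number by a modest amount. Compound 4 is therefore expected to land near compound 3, with a step of a 1.2-fold higher number from compound 3 to compound 4 (0.08 log units; within the scatter), and its estimate in this assay is 6500 nM, between 2000 nM and 22000 nM.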

Compound 4, half-maximal inhibitory concentration: 2490 nM
Compound 4: middle estimate off by 2.6-fold (0.42 log units), on the high side, within the range that was stated.
By their numbers in this assay, from the lowest: compound 4; then compound 3; then compound 2; then compound 1.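

Isopropyl in place of methoxy on the aromatic carbon gives a 2.2-fold lower number from compound 3 to compound 4 (0.34 log units; beyond the scatter) in this assay and so shows that, with the place on the ring held constant, the choice of group alone moves the number. Going by these compounds alone, the 4-isopropylphenyl group also gives the lowest number of the four compounds, with a 6.2-fold lower number from compound 2 to compound 4 (0.79 log units; beyond the scatter) and a 13-fold lower number from compound 1 to compound 4 (1.10 log units; beyond the scatter) as the only large step, so the spread across this position is wider than the first three compounds showed. No measurement at hand bears on what lies behind these steps.

The compounds shown leave open whether a longer alkyl chain at the same place would lower the number further or whether isopropyl is already near the limit of this trend. They also leave open how an amine or a carboxylic acid there would read.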